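The source may hold more compounds than are shown below. What is called first, only, known or untested is meant among the compounds shown, and "the series" means these compounds.

Measured compounds:
Compound 1, `CC(C)[C@H](NC(=O)COc1cccc2ccccc12)C(=O)N[C@@H](CC(=O)O)C(=O)CSc1nc[nH]n1` — in a functional assay on Jurkat cells (Homo sapiens) for inhibition (a higher number here means a weaker inhibitor, a lower number a stronger inhibitor), compound 1 gives > 200000 nM, which is a limit of the assay and not a number.
Compound 2, `CC(C)[C@H](NC(=O)COc1cccc2ccccc12)C(=O)N[C@@H](CC(=O)O)C(=O)CSc1nnnn1-c1ccccc1` — in this assay compound 2 gives 153000 nM.
Compound 3, `CC(C)[C@H](NC(=O)COc1cccc2ccccc12)C(=O)N[C@@H](CC(=O)O)C(=O)COc1nc2ccccc2[nH]1` — in this assay compound 3 gives > 200000 nM, which is again a limit of the assay.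

The three share the core of compound 1 and differ only in the group on a saturated chain carbon bound to a carbonyl carbon. Compound 3 stands at the limit of > 200000 nM in this assay, at which 2 of the 3 values shown sit, so its position among the measured values cannot be ranked. Two measured steps lead to it: a step that the two limits leave unreadable from compound 1 to compound 3 and an at least 1.3-fold higher number from compound 2 to compound 3 (0.11 log units; that floor lies within the scatter). Compound 4, `Cc1cc(C)nc(SCC(=O)[C@H](CC(=O)O)NC(=O)[C@@H](NC(=O)COc2cccc3ccccc23)C(C)C)n1`, carries (4,6-dimethylpyrimidin-2-yl)sulfanyl in place of (1H-benzimidazol-2-yl)oxy on a saturated chain carbon bound to a carbonyl carbon. Among the compounds with values here, no measured step introduces this pyrimidine group, so only the two steps into compound 3 bear on the change, one unreadable and one at the floor of the scatter. With every measured value at or near the limit, the expected step of a number no higher from compound 3 to compound 4 (the limit leaves the size open) is none beyond the scatter. Compound 4 is therefore estimated at 200000 nM, with an expected range from 60000 nM to 600000 nM, and its own value is expected to be reported as a limit as well.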

Compound 4, half-maximal inhibitory concentration: > 200000 nM
Compound 4 was reported as a limit; the forecaster's own chance of this, stated with the estimate: 60%; the middle value sits exactly at the limit.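

In this assay compound 4 gives > 200000 nM, which is a limit of the assay. Set against the only compound with a number, the change of group on the sulfur gives an at least 1.3-fold higher number from compound 2 to compound 4 (0.11 log units; that floor lies within the scatter), so a six-membered aromatic ring with 2 hetero atoms on the sulfur is not shown to differ from 1-phenyl-1H-tetrazol-5-yl by more than the scatter. The steps from compound 1 and compound 3 to compound 4 cannot be read, and the position now yields mostly limits: the limit of > 200000 nM in this assay, at which 3 of the 4 values shown sit.

On these data alone, how far compounds 1, 3 and 4 lie past this limit stays open, so these groups cannot be ranked against each other. Also open, as far as these compounds go, is whether a phenoxy group or an amine on this saturated chain carbon would give a clearly lower number.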